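Dimethylpyridinyl Amide Expected Beyond Cytotoxicity Limit

This account rests on a few compounds, and the source may have more. Where it says the series, first, only, none or still open, it means among the compounds named here.

Compound 3 `COc1ccc2nc(C)cc(OCC(=O)Nc3cc(F)cc(F)c3)c2c1` carries a 3,5-difluorophenyl group on its amide nitrogen. In a toxicity assay on HepG2 cells (Homo sapiens) for inhibition, read by CellTiter-Glo, with a stated time of 48 h (a higher number here means a weaker inhibitor, a lower number a stronger inhibitor), compound 3 returns only a limit, > 100000 nM. The two related compounds stand no differently: compound 2 `COc1ccc2nc(C)cc(OCC(=O)Nc3c(C)cccc3C)c2c1` gives a limit of > 100000 nM in this assay. Compound 1 `CSc1ccc2nc(C)cc(OCC(=O)Nc3cc(C)cc(C)c3)c2c1` likewise gives a limit of > 100000 nM in this assay. The step that the two limits leave unreadable from compound 2 to compound 3 therefore cannot be read in size, since both ends sit at the limit of > 100000 nM in this assay, at which 3 of the 3 values shown sit. Compound 4 `COc1ccc2nc(C)cc(OCC(=O)Nc3c(C)cncc3C)c2c1` differs from compound 3 by 3,5-dimethylpyridin-4-yl in place of 3,5-difluorophenyl on an amide-type nitrogen. Among the measured compounds shown here, no measured step gives a readable size for a change on the amide nitrogen, as the only such step, a step that the two limits leave unreadable from compound 2 to compound 3, is unreadable. With every shown value at the limit of > 100000 nM in this assay, at which 3 of the 3 values shown sit, no shift beyond the scatter in this assay is expected, and compound 4 is expected to remain at that limit as well. The estimate for compound 4 in this assay is 150000 nM, between 50000 nM and 500000 nM. The step that this estimate means is expected as a step that the limit leaves unreadable from compound 3 to compound 4.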

Compound 4, half-maximal inhibitory concentration: 12600 nM
The estimate for compound 4 lay 12-fold (1.08 log units) above the measured number; measured number below the stated range.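

In this assay, among the compounds shown here, the change on the amide nitrogen can now be read for the first time: 3,5-dimethylpyridin-4-yl in place of 3,5-difluorophenyl gives an at least 7.9-fold lower number from compound 3 to compound 4 (0.89 log units; beyond the scatter), and in place of 2,6-dimethylphenyl it gives an at least 7.9-fold lower number from compound 2 to compound 4 (0.89 log units; beyond the scatter). Each size is a lower bound only, since one end of each step is a limit, and the steps that join two limits still cannot be read. Compound 4 is thus the only compound shown that leaves the limit: the limit of > 100000 nM in this assay, at which 3 of the 4 values shown sit.

The compounds shown do not separate the ring nitrogen of 3,5-dimethylpyridin-4-yl from its two methyl groups. They also leave open whether an unsubstituted pyridin-4-yl, or a phenyl ring bearing an amine or a carboxylic acid, on the same amide nitrogen would lower the number as well.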